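This account rests on a few compounds, and the source may have more. Where it says the series, first, only, none or still open, it means among the compounds named here.

Measured compounds:
- compound 1 `Cc1cc(C)c(CN2CCc3c(Cl)cc(C(CO)c4ccon4)c(Cl)c3C2=O)c(=O)[nH]1`: 7960 nM; 273 nM (2 entries)
- compound 2 `Cc1cc(C)c(CN2CCc3c(Cl)cc([C@H](C)CO)c(Cl)c3C2=O)c(=O)[nH]1`: 129 nM

Going by the values given here, compound 2 is the only compound here with a single firm number: in an assay on cells for inhibition of histone-lysine N-methyltransferase EZH2 (Homo sapiens), read by ELISA, with a stated time of 72 h (on this read-out higher numbers stand for weaker inhibition and lower numbers for stronger inhibition), compound 2 gives 129 nM. Compound 1, which carries a different side group on the same core, has been run more than once, and the several entries of compound 1 in this assay, 7960 nM; 273 nM (2 entries) shows two entries far apart from each other, so it offers no clean point of comparison for compound 2.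

Compound 3 `Cc1cc(C)c(CN2CCc3c(Cl)cc([C@@H](C)CO)c(Cl)c3C2=O)c(=O)[nH]1` has not been measured. Compared with compound 2, (the two compounds have the same atoms and bonds and differ only in configuration as drawn: 1 of 1 stereo elements differ; a stereocentre at a saturated chain carbon is drawn S in compound 2 and R in compound 3). Nothing is added or taken away; the molecule is the mirror-image form at that single carbon. Among the compounds with values here, no measured pair in this set shows what such a flip does, so the size of the step in this assay is open. Mirror-image pairs often differ a great deal, with one form carrying most of the activity, and compound 2 has no sign of being the weak partner.

The estimate for compound 3 is 900 nM, within a range of 150 nM to 6000 nM, corresponding to an expected step of a 7.0-fold higher number from compound 2 to compound 3 (0.84 log units; beyond the scatter) toward weaker inhibition.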

Compound 3, half-maximal inhibitory concentration: 1040 nM
Compound 3: middle estimate off by 1.2-fold (0.06 log units), on the low side, and the stated range covers the measured number.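

In this assay, going by these compounds alone, inverting the one stereocentre at a saturated chain carbon from S to R gives an 8.1-fold higher number from compound 2 to compound 3 (0.91 log units; beyond the scatter), the first clean reading of what the spatial arrangement at this carbon is worth, with the S form, compound 2, the stronger of the pair. Compound 1 could not give such a reading, because its entries lie too far apart to serve as a reference: the several entries of compound 1 in this assay, 7960 nM; 273 nM (2 entries). Here the gap can be assigned to the arrangement at that single carbon, because nothing else changes between the two compounds: the fact that compounds 2 and 3 differ only in the configuration as drawn

Going by these compounds, whether the two mirror forms of compound 1, which is drawn without a set configuration at its chain carbon, split in the same direction stays open. So does the question of whether the preference for the S form survives when the alcohol on the chain gives way to a primary amine or a carboxylic acid, or when the chain itself is replaced by a longer chain.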